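The source may report more compounds than this note shows. Statements on the series, on what has been measured and on what is new or still open speak of the compounds shown alone.

Compound 2 `CC(C)c1onc(-c2c(Cl)cccc2Cl)c1COc1ccc(-c2nc3ccc(C(=O)O)cc3n2-c2ccc(F)cc2)cc1` gives 15.1 nM in an assay on isolated protein for agonist activity at Bile acid receptor (Homo sapiens), read by TR-FRET (on this read-out lower numbers stand for an effect already at smaller amounts and higher numbers for an effect only at larger amounts of compound), the lowest of the three numbers measured; compound 3 `CCC(CC)n1c(-c2ccc(OCc3c(-c4c(Cl)cccc4Cl)noc3C(C)C)cc2Cl)nc2ccc(C(=O)O)cc21` gives 21.6 nM, within the scatter of compound 2, while compound 1 `CCC(CC)n1c(-c2ccc(OCc3c(-c4c(Cl)cccc4Cl)noc3C(C)C)cc2F)nc2ccc(C(=O)O)cc21` gives 69.3 nM, beyond it. Going by the values given here, the only step across a single change, a 3.2-fold lower number from compound 1 to compound 3 (0.51 log units; beyond the scatter), concerns the halogen on an aromatic carbon and does not touch the aromatic nitrogen. Compound 4 `CC(C)c1onc(-c2c(Cl)cccc2Cl)c1COc1ccc(-c2nc3ccc(C(=O)O)cc3n2C2CCCCCC2)cc1` carries cycloheptyl in place of 4-fluorophenyl on an aromatic nitrogen. Among the compounds with values here, no measured pair isolates this change; compounds 1 and 3 show that a non-aromatic group on that nitrogen still gives low numbers. A step within the scatter is therefore expected, a 1.3-fold higher number from compound 2 to compound 4 (0.12 log units; within the scatter). Compound 4 is estimated at 20 nM, with a range of 8 nM to 50 nM.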

Compound 4, half-maximal effective concentration: 113 nM
Estimate against measurement, compound 4: 5.7-fold (0.75 log units) below, outside the stated range (above it).
By their numbers in this assay, from the lowest: compounds 2 and 3 (each within the scatter of the next); then compounds 1 and 4 (each within the scatter of the next).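

In this assay, the aromatic nitrogen proves sensitive to the exchange of 4-fluorophenyl for cycloheptyl, with a 7.5-fold higher number from compound 2 to compound 4 (0.87 log units; beyond the scatter). The step lies beyond the scatter, although both groups have 7 heavy atoms and neither has a hydrogen-bond donor or acceptor, so these counts alone do not keep the number low at this position. No available evidence accounts for the step. The compounds shown leave open whether the loss follows the fluorine, the aromatic ring or the ring size. Phenyl and cyclohexyl on this nitrogen would help separate these possibilities.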